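The source may hold more compounds than are shown below. What is called first, only, known or untested is meant among the compounds shown, and "the series" means these compounds.

Measured compounds in an assay for inhibition of serine/threonine-protein kinase PAK 4 (Homo sapiens), read by FRET and Z'-LYTE, with a stated time of 60 min, tested at 50 uM, in the presence of a further agent that is not named here; on this read-out higher numbers stand for a stronger effect at the one concentration tested and lower numbers for a weaker effect:
compound 1 `CCOC(=O)N1CCN(C(=O)c2nc(Nc3cc(C4CC4)[nH]n3)c3cc(Cl)ccc3n2)C[C@H]1C`: 93.4%
compound 2 `CC(OC(=O)C(C)C)OC(=O)N1CCN(C(=O)c2nc(Nc3cc(C4CC4)[nH]n3)c3cc(Cl)ccc3n2)C[C@H]1C`: 71.7%
compound 3 `C[C@@H]1CN(C(=O)c2nc(Nc3cc(C4CC4)[nH]n3)c3cc(Cl)ccc3n2)CCN1C(=O)OCc1ccccc1`: 96%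

Compound 3 gives the highest of the three numbers. Its nearest neighbour is compound 1, a number 2.6 percentage points higher from compound 1 to compound 3 (within the scatter), within the scatter; the furthest is compound 2, a number 24.3 percentage points higher from compound 2 to compound 3 (beyond the scatter), beyond it.

Compound 4 `C[C@@H]1CN(C(=O)c2nc(Nc3cc(C4CC4)[nH]n3)c3cc(Cl)ccc3n2)CCN1C(=O)OCC(Cl)(Cl)Cl` is not yet tested in this assay. Change from compound 3: trichloromethyl in place of phenyl on a saturated chain carbon bound to an oxygen next to a carbonyl group. Both measured steps alter the group on the saturated chain carbon bound to an oxygen next to a carbonyl group: a number 2.6 percentage points higher from compound 1 to compound 3 (within the scatter) stayed within the scatter, while a number 24.3 percentage points higher from compound 2 to compound 3 (beyond the scatter) was modest. The change to compound 4 is of the smaller kind, so no step beyond the scatter is expected. The estimate for compound 4 is 90%, between 74% and 98%. The expected step, a number 6 percentage points lower from compound 3 to compound 4 (within the scatter), lies within the scatter.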

Compound 4, a percentage reported as inhibition, at one concentration (the size of the read-out at that concentration, not a potency): 82.8%
Beside the measured number, compound 4's estimate is 7.2 percentage points above it; the range from low to high includes it.
By their numbers in this assay, from the lowest: compound 2; then compound 4; then compounds 1 and 3 (each within the scatter of the next).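

The position responds to a change of group, although phenyl and methyl had stayed within the scatter of each other: in this assay, trichloromethyl in place of phenyl gives a number 13.2 percentage points lower from compound 3 to compound 4 (beyond the scatter), and trichloromethyl in place of methyl gives a number 10.6 percentage points lower from compound 1 to compound 4 (beyond the scatter). The 2,2,2-trichloroethyl group still reads apart from the 1-((isopropylcarbonyl)oxy)ethyl group, with a number 11.1 percentage points higher from compound 2 to compound 4 (beyond the scatter). Nothing at hand bears on what lies behind these steps.

Going by these compounds, whether the chlorine atoms as such set these steps stays open; a 2-chloroethyl or 2,2,2-trifluoroethyl group here would test that. All readings come from one concentration, so none gives a potency.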